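Removing the fluorine from compound 3

The source may report more compounds than this note shows. Statements on the series, on what has been measured and on what is new or still open speak of the compounds shown alone.

Compound 3 `COc1ccc(-c2cnc3nc(N)nc(N4CCN(c5ccc(F)cc5)CC4)c3n2)cc1OC` stands highest of the three numbers in a functional assay on cells (T-cell, Homo sapiens) for inhibition (on this read-out lower numbers stand for stronger inhibition and higher numbers for weaker inhibition), at 100 nM; its nearest neighbour is compound 1 `COc1ccc(-c2cnc3nc(N)nc(N4CCN(C(=O)NCc5ccc(F)cc5)CC4)c3n2)cc1OC` with 37 nM, and compound 2 `COc1ccc(-c2cnc3nc(N)nc(N4CCN(C(=O)Nc5ccc(C)cc5)CC4)c3n2)cc1OC` lies furthest away with 0.8 nM. Compound 4 `COc1ccc(-c2cnc3nc(N)nc(N4CCN(c5ccccc5)CC4)c3n2)cc1OC` differs from compound 3 by hydrogen in place of fluoro on an aromatic carbon. For the measured compounds named here, none of the measured steps touches this part of the molecule: a 46-fold lower number from compound 1 to compound 2 (1.67 log units; beyond the scatter), a 130-fold higher number from compound 2 to compound 3 (2.10 log units; beyond the scatter) and a 2.7-fold higher number from compound 1 to compound 3 (0.43 log units; beyond the scatter) each exchange the whole group on the amine nitrogen in a ring, not one atom on a distant aromatic carbon. With nothing bearing directly on the fluoro, only a small step, if any, is expected for compound 4, no change at the digits printed from compound 3 to compound 4 (within the scatter). Compound 4 is therefore estimated at 100 nM, with a range from 40 nM to 250 nM.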

Compound 4, half-maximal inhibitory concentration: 400 nM
Compound 4: the middle estimate sits 4.0-fold (0.60 log units) below what was measured; measured number above the stated range.
By their numbers in this assay, from the lowest: compound 2; then compound 1; then compound 3; then compound 4.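

In this assay, swapping one fluorine on this aromatic carbon for hydrogen gives a 4.0-fold higher number from compound 3 to compound 4 (0.60 log units; beyond the scatter) and so shows that this single atom, para to a large group, does count. That step is still small beside exchanging the whole group on the ring nitrogen, which gives a 500-fold higher number from compound 2 to compound 4 (2.70 log units; beyond the scatter) and an 11-fold higher number from compound 1 to compound 4 (1.03 log units; beyond the scatter). Nothing at hand explains why the fluorine matters.

Open, from the compounds shown here alone, is whether a chloro or a nitrile on this carbon would do as well as the fluoro or better. Also open, going by these compounds, is whether the fluoro would count as much on the phenyl of a urea such as compound 2.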